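This account rests on a few compounds, and the source may have more. Where it says the series, first, only, none or still open, it means among the compounds named here.

Compound 1 `Cc1ncn2c(O)nncc12`, compound 2 `Cc1ncn2c(S)nncc12` and compound 3 `CSc1nncc2c(C)ncn12` share one core and differ only in the group carried on a single aromatic carbon. In a functional assay for inhibition, with Homo sapiens as the target (on this read-out lower numbers stand for stronger inhibition and higher numbers for weaker inhibition), compound 1 gives > 48000 nM, which is a limit of the assay and not a number. In this assay compound 2 gives > 48000 nM, again a limit. Compound 3 gives > 48000 nM in this assay, once more a limit. Compound 3 therefore stands nowhere on a scale of numbers: it sits with the other two at the limit. The steps a step that the two limits leave unreadable from compound 1 to compound 2, a step that the two limits leave unreadable from compound 1 to compound 3 and a step that the two limits leave unreadable from compound 2 to compound 3 cannot be read in size because every value sits at the limit of > 48000 nM in this assay, at which 3 of the 3 values shown sit.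

Compound 4 `Cc1ncn2c(N(C)C)nncc12` differs from compound 3 by dimethylamino in place of methylsulfanyl on an aromatic carbon. The measured steps bear on this change only in that three exchanges at the same aromatic carbon, hydroxy, sulfanyl and methylsulfanyl, have all left the value at the limit, and none of them gives a readable size. No step beyond the scatter is expected in this assay, in either direction, and the most likely outcome is another limit. Compound 4 is therefore estimated to give 60000 nM in this assay, with a range from 12000 nM to 300000 nM. For compound 4 this estimate means an expected step that the limit leaves unreadable from compound 3 to compound 4.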

Compound 4, half-maximal inhibitory concentration: > 48000 nM
Compound 4 was reported as a limit (the forecaster's own chance of this, stated with the estimate: 85%); the middle value does not contradict the limit.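

For the compounds shown here, no step from compound 1, compound 2 or compound 3 to compound 4 can be read in size in this assay, because all four compounds stand at the same limit: the limit of > 48000 nM in this assay, at which 4 of the 4 values shown sit.

The compounds shown leave open whether any group on this aromatic carbon, or any change elsewhere on the shared core, would give a readable value in this assay.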